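Amide variation on the shared core: cytotoxicity working notes

The source may hold more compounds than are shown below. What is called first, only, known or untested is meant among the compounds shown, and "the series" means these compounds.

Going by the values given here, in an ADME assay on L6 cells (Rattus norvegicus) for cytotoxicity, read by resazurin assay, with a stated time of 72 h (a higher number here means that more compound is needed for the effect, a lower number that less compound is needed), compound 3 `CC1=C(C(=O)N2CCCCC2)C(=O)/C(=C\c2cc(C)n(-c3ccccc3C(F)(F)F)c2C)N1` gives the lowest of the three numbers so far, at 26000 nM. Compound 2 `CC1=C(C(N)=O)C(=O)/C(=C\c2cc(C)n(-c3ccccc3C(F)(F)F)c2C)N1` gives 30000 nM, and compound 1 `CC1=CC(=O)/C(=C\c2cc(C)n(-c3ccccc3C(F)(F)F)c2C)N1` gives 54000 nM. The steps among them are a 1.8-fold lower number from compound 1 to compound 2 (0.26 log units; within the scatter), a 1.2-fold lower number from compound 2 to compound 3 (0.06 log units; within the scatter) and a 2.1-fold lower number from compound 1 to compound 3 (0.32 log units; beyond the scatter). Compound 4 `CC1=C(C(=O)NCCO)C(=O)/C(=C\c2cc(C)n(-c3ccccc3C(F)(F)F)c2C)N1` differs from compound 3 by (2-hydroxyethyl)amino in place of piperidin-1-yl on a carbonyl carbon. Among the compounds with values here, the one step that bears directly on this change is the earlier amide variation, a 1.2-fold lower number from compound 2 to compound 3 (0.06 log units; within the scatter), which stayed within the scatter. Within the data shown here, with only that small step to go on, compound 4 is expected to sit near compound 3, with a 1.2-fold higher number from compound 3 to compound 4 (0.06 log units; within the scatter) as the expected step, likely not beyond the scatter. The estimate for compound 4 is 30000 nM, with a range from 15000 nM to 60000 nM.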

Compound 4, half-maximal effective concentration in the L6 assay: 49000 nM
For compound 4 the middle estimate is 1.6-fold (0.21 log units) below the measured one; measured number inside the range.
By their numbers in the L6 assay, from the lowest: compounds 3, 2, 4 and 1 (each within the scatter of the next, the first and the last beyond it).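

In the L6 assay, compound 4 gives 49000 nM; the change from (piperidin-1-yl)carbonyl to (2-hydroxyethyl)carbamoyl gives a 1.9-fold higher number from compound 3 to compound 4 (0.28 log units; within the scatter), and 2-hydroxyethyl on the amide-type nitrogen gives a 1.6-fold higher number from compound 2 to compound 4 (0.21 log units; within the scatter), so neither step leaves the scatter. Going by these compounds alone, with (2-hydroxyethyl)carbamoyl on the double-bonded ring carbon the step is a 1.1-fold lower number from compound 1 to compound 4 (0.04 log units; within the scatter), whereas (piperidin-1-yl)carbonyl there gave the only step beyond the scatter, a 2.1-fold lower number from compound 1 to compound 3 (0.32 log units; beyond the scatter). Nothing available accounts for these steps.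

In a physicochemical assay for lipophilicity, read by HPLC, at pH 7.4 (a lower number here means a more polar compound, a higher number a more lipophilic compound), compound 3 gives "not determined" (no result reported) and compound 4 gives "not determined" (no result reported), so no step can be read there. On these data alone, whether an amine or a carboxylic acid on the amide chain would move the number beyond the scatter remains open.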